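Swapping phenoxy for 4-methoxyphenyl on compound 2

The source may hold more compounds than are shown below. What is called first, only, known or untested is meant among the compounds shown, and "the series" means these compounds.

Of the compounds shown here, two have been measured in a physicochemical assay for solubility, with a stated time of 18 h, at pH 7.4; on this read-out higher numbers stand for higher solubility and lower numbers for lower solubility. Compound 1 `COc1ccc(F)cc1CNCCCNc1ccnc2cc(Cc3ccc(C#N)cc3)ccc12` gives 4200 nM. Compound 2 `COc1cccc(CNCCCNc2ccnc3cc(Oc4ccccc4)ccc23)c1O` gives 14500 nM, the higher of the two numbers, beyond the scatter from compound 1. Compound 3 `COc1ccc(-c2ccc3c(NCCCNCc4cccc(OC)c4O)ccnc3c2)cc1` differs from compound 2 by one change: 4-methoxyphenyl in place of phenoxy on an aromatic carbon. Among the measured compounds shown here, no measured pair shows this change, so its effect is uncertain; on this assay a step toward lower solubility from compound 2 to compound 3 is expected, of moderate size, estimated as a 2.9-fold lower number from compound 2 to compound 3 (0.46 log units; beyond the scatter). Compound 3 is therefore expected to give about 5000 nM, within a range of 1500 nM to 15000 nM.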

Compound 3, solubility: 32000 nM
Estimate against measurement, compound 3: 6.4-fold (0.81 log units) below; measured number outside the range, above it.
By their numbers in this assay, from the lowest: compound 1; then compound 2; then compound 3.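

In this assay, 4-methoxyphenyl in place of phenoxy on this aromatic carbon moves the number upward, a 2.2-fold higher number from compound 2 to compound 3 (0.34 log units; beyond the scatter), a modest step but beyond the scatter. Among the compounds shown here, this is the first step that can be read at this position, and it shows that the larger group can stand here without a loss on this read-out. No available evidence accounts for the direction of the step. As far as these compounds go, what a plain phenyl or a morpholine would give at this position remains open, and so does whether the methoxy group contributes to the step at all.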